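Propargyl to propyl change carried onto a second core

The compounds below may be only part of what the source reports. "The series", "measured", "known", "first", "only" and "open" are said of these compounds alone.

Compound 1 `C#CCOc1ccc(C(=O)c2ccc(Cn3ccnc3)cc2)cc1` and compound 2 `CCCOc1ccc(C(=O)c2ccc(Cn3ccnc3)cc2)cc1` share one core; compound 3 `C#CCOc1ccc(C(=O)c2cccc(Cn3ccnc3)c2)cc1` and the unmeasured compound 4 `CCCOc1ccc(C(=O)c2cccc(Cn3ccnc3)c2)cc1` share another, and the difference between the two cores is not broken down here. In an assay on isolated protein for inhibition of Aromatase (Homo sapiens), read by fluorescence, with stated times of 10 min and 60 min (on this read-out lower numbers stand for stronger inhibition and higher numbers for weaker inhibition), compound 1 gives 210 nM, compound 2 gives 374 nM and compound 3 gives 650 nM. The change from compound 1 to compound 2, (ethyl in place of ethynyl on a saturated chain carbon bound to an oxygen on an aromatic ring), produced a 1.8-fold higher number from compound 1 to compound 2 (0.25 log units; within the scatter). Compound 3 sits apart from compound 1 beyond the scatter and from compound 2 within it. Compound 4 carries the same change at the same place, (ethyl in place of ethynyl on a saturated chain carbon bound to an oxygen on an aromatic ring). Going by the values given here, compound 4 is expected to show a 1.8-fold higher number from compound 3 to compound 4 (0.25 log units; within the scatter), a step of about the earlier size, because a 1.8-fold higher number from compound 1 to compound 2 (0.25 log units; within the scatter) is the only precedent for this change. Compound 4 is therefore estimated at 1150 nM, expected to fall between 500 nM and 2600 nM.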

Compound 4, half-maximal inhibitory concentration: 2 nM
For compound 4 the middle estimate is 580-fold (2.76 log units) above the measured one; measured number below the stated range.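

Going by these compounds alone, on the core of compound 3, the propargyl to propyl change gives a 330-fold lower number from compound 3 to compound 4 (2.51 log units; beyond the scatter), so in this assay the step on the core of compound 1 is no guide to the step on the second core: the same change on two cores in this assay, a 1.8-fold higher number (0.25 log units; within the scatter) from compound 1 to compound 2 and a 330-fold lower number (2.51 log units; beyond the scatter) from compound 3 to compound 4, 580-fold (2.76 log units) apart, beyond the scatter of two such steps. Across these four compounds, the outcome of this change therefore depends on the core. This does not show which feature of the core is responsible, and one pair on each of two cores gives no rule for any further core.

As far as these compounds go, it remains open whether a longer chain such as butoxy would keep the low number of compound 4. The same applies to an amine in place of propoxy on this core.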